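Heteroaryl amide variation on a shared sulfonamide scaffold

This account rests on a few compounds, and the source may have more. Where it says the series, first, only, none or still open, it means among the compounds named here.

Measured compounds:
compound 1 `O=C(NCc1ccc(S(=O)(=O)N2CCCCC2)cc1)c1cc2cnccc2s1` — 150 nM
compound 2 `O=C(NCc1ccc(S(=O)(=O)N2CCCCC2)cc1)c1ccn2cncc2c1` — 1700 nM
compound 3 `O=C(NCc1ccc(S(=O)(=O)N2CCCCC2)cc1)c1cc2ccncc2[nH]1` — 1000 nM

In an assay for inhibition of Nicotinamide phosphoribosyltransferase (Homo sapiens), read by mass spectrometry, with stated times of 15 min and 30 min (on this read-out lower numbers stand for stronger inhibition and higher numbers for weaker inhibition), compound 3 stands second highest of the three numbers. Its nearest neighbour is compound 2, and the step of a 1.7-fold lower number from compound 2 to compound 3 (0.23 log units; within the scatter) lies within the scatter, so the two cannot be ordered. Against compound 1 the step of a 6.7-fold higher number from compound 1 to compound 3 (0.82 log units; beyond the scatter) lies beyond the scatter.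

Compound 4 `O=C(NCc1ccc(S(=O)(=O)N2CCCCC2)cc1)c1cnc2nccn2c1` is not yet measured in this assay. It differs from compound 3 in one place: a group of 9 heavy atoms (6 carbon, 3 nitrogen; one five-membered aromatic ring with 2 hetero atoms, one six-membered aromatic ring with 2 hetero atoms) in place of a group of 9 heavy atoms (7 carbon, 2 nitrogen; one five-membered aromatic ring with 1 hetero atom, one six-membered aromatic ring with 1 hetero atom), on a carbonyl carbon

Among the compounds with values here, two steps bear on this change. The step of an 11-fold higher number from compound 1 to compound 2 (1.05 log units; beyond the scatter) and the step of a 6.7-fold higher number from compound 1 to compound 3 (0.82 log units; beyond the scatter) both show that exchanging the core of compound 1 for a group carrying 2 nitrogen atoms raises the number, and the step of a 1.7-fold lower number from compound 2 to compound 3 (0.23 log units; within the scatter) shows the two such groups sit together. The entering group of compound 4 shares with the group of compound 2 a five-membered aromatic ring with 2 hetero atoms and adds a further nitrogen while losing the hydrogen-bond donor. The step of a 2.0-fold higher number from compound 3 to compound 4 (0.30 log units; within the scatter) is therefore expected to be no larger than the scatter, or a modestly higher number. The estimate for compound 4 in this assay is 2000 nM, with a range from 600 nM to 7000 nM.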

Compound 4, half-maximal inhibitory concentration: 3 nM
The estimate for compound 4 lay 670-fold (2.82 log units) above the measured number, outside the stated range (below it).
By their numbers in this assay, from the lowest: compound 4; then compound 1; then compounds 3 and 2 (each within the scatter of the next).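

In this assay, this place on the carbonyl carbon tolerates far more variation than compounds 1, 2 and 3 suggested: a 330-fold lower number from compound 3 to compound 4 (2.52 log units; beyond the scatter), a 570-fold lower number from compound 2 to compound 4 (2.75 log units; beyond the scatter) and a 50-fold lower number from compound 1 to compound 4 (1.70 log units; beyond the scatter), which makes compound 4 the strongest inhibitor of the four. Compound 2 also carries a five-membered aromatic ring with 2 hetero atoms, so that ring alone does not go with a low number; the change to a six-membered aromatic ring with 2 hetero atoms is the feature printed only for compound 4. Compound 4 also goes against the earlier reading that sulfur-free groups raise the number. No measurement here gives a reason for the size of these steps.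

Whether the added nitrogen or the lost hydrogen-bond donor matters more stays open, as no compound shown changes only one of them. Also open, as far as these compounds go, is whether the low number survives a methyl group or an amine on the entering group.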